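Trading a hydroxymethyl for a hydroxy on the thiadiazole ring

A few compounds are considered here, and "the series" means these few. Any claim that something is new, unique, unknown or untested is made for them only; others in the source may bear on it.

Measured compounds:
compound 1, `Cc1cccc(OC2CCN(c3ccc(-n4ccnc4)nn3)CC2)c1`, 251 nM
compound 2, `OCc1nnc(-c2ccc(N3CCC(Oc4ccccc4C(F)(F)F)CC3)nn2)s1`, 3.2 nM
compound 3, `Brc1cccc(OC2CCN(c3ccc(-n4ccnc4)nn3)CC2)c1`, 23 nM

In an assay on microsomes from liver for inhibition of acyl-CoA desaturase 1 (Rattus norvegicus) (a higher number here means a weaker inhibitor, a lower number a stronger inhibitor), compound 2 gives the lowest number of the three and is therefore the strongest inhibitor measured here; compound 3 sits nearest to it and compound 1 furthest, both gaps being beyond the scatter. Compound 4, `Oc1nnc(-c2ccc(N3CCC(Oc4ccccc4C(F)(F)F)CC3)nn2)s1`, has not yet been measured. It differs from compound 2 by hydroxy in place of hydroxymethyl on an aromatic carbon. Among the compounds with values here, the one measured step, an 11-fold lower number from compound 1 to compound 3 (1.04 log units; beyond the scatter), concerns a different part of the molecule, the aryl ring at the far end of the shared core, and so says nothing direct about a change on the thiadiazole. Within the data shown here, the data hold no pair that alters this position. Among the measured compounds shown here, with no step bearing on it, the expectation is a change no larger than the scatter, or at most a slight weakening, which is the step meant by a 1.9-fold higher number from compound 2 to compound 4 (0.27 log units; within the scatter). Compound 4 is thus estimated at 6 nM, within a range from 1.5 nM to 25 nM.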

Compound 4, half-maximal inhibitory concentration: 6.1 nM
The estimate for compound 4 lay 1.0-fold (0.01 log units) below the measured number; the measured number falls inside the stated range.
By their numbers in this assay, from the lowest: compounds 2 and 4 (each within the scatter of the next); then compound 3; then compound 1.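

In this assay, trading the hydroxymethyl for a hydroxy on the thiadiazole ring gives a 1.9-fold higher number from compound 2 to compound 4 (0.28 log units; within the scatter), so this step does not stand out from the ordinary spread of repeated measurements. This is the only pair shown that alters this position, and it indicates that, on this scaffold, the carbon of the hydroxymethyl can be dropped without a measurable change in this read-out, while the count of one hydrogen-bond donor and one hydrogen-bond acceptor stays the same. No measurement shown gives a reason for this result.

On these data alone, how much further this position can be changed stays open, as an amine, a carboxylic acid or a longer chain there could read quite differently. A plain hydrogen or a methyl in the same place would show whether the oxygen of these two groups matters at all.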